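The source may report more compounds than this note shows. Statements on the series, on what has been measured and on what is new or still open speak of the compounds shown alone.

Three compounds sharing one core were measured in a functional assay on A-375 cells (Homo sapiens) for antiproliferative activity, read by CCK-8 assay, with a stated time of 72 h, tested at 2 uM; on this read-out lower numbers stand for a weaker effect and higher numbers for a stronger effect at the one concentration tested. Compound 1 `CCN(Cc1ccncc1)C(=S)SCc1ccc(C(=O)Nc2ccccc2N)cc1` gives 67.2% in this assay. Compound 2 `Nc1ccccc1NC(=O)c1ccc(CSC(=S)N2CCN(Cc3ccncc3)CC2)cc1` gives 33.1% in this assay, the second highest of the three numbers: compound 1 stands higher by a margin beyond the scatter, and compound 3 `Nc1ccccc1NC(=O)c1ccc(CSC(=S)N2CCN(C(c3ccccc3)c3ccccc3)CC2)cc1`, which gives 8.7% in this assay, stands lower by a margin also beyond the scatter. Going by the values given here, no single-change step between the measured compounds is available, so the comparison of compound 2 with compound 4 rests on the change alone.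

Compound 4 `Cc1ccc(N2CCN(C(=S)SCc3ccc(C(=O)Nc4ccccc4N)cc3)CC2)cc1` differs from compound 2 in one place: 4-methylphenyl in place of (pyridin-4-yl)methyl on an amine nitrogen in a ring. Among the compounds with values here, no measured pair shows the effect of such a change, and the two measured neighbours of compound 2 lie on either side of it. For compound 4 the step in this assay is therefore expected to be small, a number 5.1 percentage points lower from compound 2 to compound 4 (within the scatter), and within the scatter. Compound 4 is estimated at 28% in this assay, with a range from 8% to 50%.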

Compound 4, a percentage reported as inhibition, at one concentration (the size of the read-out at that concentration, not a potency): 25.8%
Compound 4: the middle estimate sits 2.2 percentage points above what was measured; measured number inside the range.
By their numbers in this assay, from the lowest: compound 3; then compounds 4 and 2 (each within the scatter of the next); then compound 1.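

Going by these compounds alone, the swap of (pyridin-4-yl)methyl for 4-methylphenyl on the amine nitrogen in the ring gives the first single-change reading: in this assay it yields a number 7.3 percentage points lower from compound 2 to compound 4 (within the scatter). At this position, a group with a hydrogen-bond acceptor and a carbon-only aromatic group of equal heavy-atom count therefore cannot be told apart at the one concentration tested. Nothing measured here explains this outcome.

The compounds shown leave open what a carboxylic acid, an aminoethyl chain or a plain methyl on the same nitrogen would give, as each would alter this position more than an exchange of one six-membered aromatic ring for another. From the compounds shown here alone, whether compound 2 and compound 4 would also stay together across a range of concentrations remains open too.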